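This account rests on a few compounds, and the source may have more. Where it says the series, first, only, none or still open, it means among the compounds named here.

Compound 1, with structure `O=C(O)c1cc(-n2cccc2)ccc1O`, is the starting point of this step. In a functional assay on the whole organism with Rattus norvegicus as the target (on this read-out higher numbers stand for an effect only at larger amounts of compound and lower numbers for an effect already at smaller amounts), compound 1 gives 30 mg/kg, the lowest of the two plain numbers shown. Compound 2 `CC(=O)Oc1ccc(-n2cccc2)cc1C(=O)O` carries an acetyl in place of hydrogen on the ring oxygen, and in this assay compound 2 gives 35 mg/kg; the step of a 1.2-fold higher number from compound 1 to compound 2 (0.07 log units; within the scatter) is within the scatter. Compound 3 `O=C(O)c1ccc(-c2cscn2)cc1O`, which bears a different five-membered ring on the shared core, is reported in this assay only as a limit of the assay, > 80 mg/kg, and not as a number (the limit of > 80 mg/kg in this assay, at which 1 of the 3 values shown sits).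

The compound to be made is compound 4 `O=C(O)c1cc(-n2ccnc2)ccc1O`. It differs from compound 1 in one place: 1H-imidazol-1-yl in place of 1H-pyrrol-1-yl on an aromatic carbon. Only one measured step exists among these compounds, and it changes the oxygen, not the five-membered ring, so it does not bear directly on this change; its size, a 1.2-fold higher number from compound 1 to compound 2 (0.07 log units; within the scatter), was within the scatter. Among the compounds with values here, no measured step tells how swapping the five-membered ring on this core shifts the read-out.

Within the data shown here, with no step to lean on, the expectation for compound 4 in this assay is a number near that of compound 1, estimated at 40 mg/kg, with a range from 15 mg/kg to 100 mg/kg. The step this estimate means is expected to be a 1.3-fold higher number from compound 1 to compound 4 (0.12 log units; within the scatter).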

Compound 4, dose for half-maximal effect: 65 mg/kg
Beside the measured number, compound 4's estimate is 1.6-fold (0.21 log units) below it; low and high end bracket the measured number.
By their numbers in this assay, from the lowest: compounds 1, 2 and 4 (each within the scatter of the next, the first and the last beyond it). At a limit, above all of these: compound 3.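

Compound 1 and compound 4 have the same number of heavy atoms in this group, yet the position on an aromatic carbon, meta to a carboxy group and para to a hydroxy group, still responds to the ring placed there. In this assay, 1H-imidazol-1-yl in place of 1H-pyrrol-1-yl gives a 2.2-fold higher number from compound 1 to compound 4 (0.34 log units; beyond the scatter), so replacing one ring carbon with a nitrogen means a larger dose is needed for the same effect, though the step is modest. This is the first step among these compounds to pass the scatter, and nothing given here explains why this exchange shifts the read-out.

As far as these compounds go, it remains open whether a different group at this position, such as a phenyl ring, a 1H-pyrazol-1-yl ring or an amine, would bring the number closer to that of compound 1 or move it further away. Also open, from the compounds shown here alone, is whether acetyl in place of hydrogen on the ring oxygen would leave compound 4 as little changed as it left compound 1.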